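Urea aryl variation on a shared core

The source may report more compounds than this note shows. Statements on the series, on what has been measured and on what is new or still open speak of the compounds shown alone.

The series keeps one shared core and varies the aryl group on the urea nitrogen. Compound 1 `O=C(Nc1ccccc1)Nc1nnc(Sc2ncnc3scc(-c4ccncc4)c23)s1` gives 23300 nM in a functional assay on T47D cells (Homo sapiens) for antiproliferative activity, read by MTT assay, with a stated time of 48 h; a higher number here means a weaker inhibitor, a lower number a stronger inhibitor. Compound 2 `Cc1cccc(NC(=O)Nc2nnc(Sc3ncnc4scc(-c5ccncc5)c34)s2)c1` gives 27200 nM in this assay, and compound 3 `O=C(Nc1ccc(Cl)c(Cl)c1)Nc1nnc(Sc2ncnc3scc(-c4ccncc4)c23)s1` gives 14600 nM in this assay. Compound 3 stands lowest of the three numbers, yet its steps to both others stay inside the scatter: a 1.6-fold lower number from compound 1 to compound 3 (0.20 log units; within the scatter) and a 1.9-fold lower number from compound 2 to compound 3 (0.27 log units; within the scatter); likewise a 1.2-fold higher number from compound 1 to compound 2 (0.07 log units; within the scatter) is inside it. Compound 4 `O=C(Nc1ccc(Cl)cc1)Nc1nnc(Sc2ncnc3scc(-c4ccncc4)c23)s1` is not yet measured. Its difference from compound 3 is hydrogen in place of chloro on an aromatic carbon, which cuts the 3,4-dichlorophenyl back to 4-chlorophenyl. The entry of both chloro groups gave only a 1.6-fold lower number from compound 1 to compound 3 (0.20 log units; within the scatter), so removing one of them is expected to leave the number between those of compound 1 and compound 3, with no step beyond the scatter. For compound 4 the expected value in this assay is 18000 nM, with a range from 9000 nM to 36000 nM. The expected step is a 1.2-fold higher number from compound 3 to compound 4 (0.09 log units; within the scatter), no change beyond the scatter.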

Compound 4, half-maximal inhibitory concentration: 23300 nM
Compound 4: middle estimate off by 1.3-fold (0.11 log units), on the low side; the measured number falls inside the stated range.
By their numbers in this assay, from the lowest: compounds 3, 1, 4 and 2 (each within the scatter of the next).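

Compound 4 lets the two chloro groups of compound 3 be read one at a time in this assay: the chloro of the 4-chlorophenyl alone gives no change at the digits printed from compound 1 to compound 4 (within the scatter) and hydrogen in place of the other chloro, ortho to a chloro group, gives a 1.6-fold higher number from compound 3 to compound 4 (0.20 log units; within the scatter) so neither single chloro moves the number beyond the scatter. The 4-chlorophenyl set against the 3-methylphenyl gives a 1.2-fold lower number from compound 2 to compound 4 (0.07 log units; within the scatter) and all four aryl groups on the urea nitrogen therefore lie within the scatter of one another. Nothing available gives a reason for this flat result.

From the compounds shown here alone, whether an amine or a carboxylic acid on this aryl ring, or a longer chain in place of the ring, would move the number beyond the scatter stays open. Also open, going by these compounds, is how far changes to the shared core, rather than to the urea aryl group, would shift these numbers.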